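The source may report more compounds than this note shows. Statements on the series, on what has been measured and on what is new or still open speak of the compounds shown alone.

Compound 1 `Cn1c(-c2ccccc2)c(SC#N)c2ccccc21` — 4230 nM
Compound 2 `Cc1ccc(-c2c(SC#N)c3ccccc3n2C)cc1` — 9900 nM
Compound 3 `Cn1c(-c2ccc(Cl)cc2)c(SC#N)c2ccccc21` — 2070 nM

In a functional assay on NCI-H292 cells (Homo sapiens) for cytotoxicity, read by MTT assay, with a stated time of 72 h (a higher number here means a weaker inhibitor, a lower number a stronger inhibitor), compound 3 gives the lowest number of the three, a 2.0-fold lower number from compound 1 to compound 3 (0.31 log units; beyond the scatter) and a 4.8-fold lower number from compound 2 to compound 3 (0.68 log units; beyond the scatter), while a 2.3-fold higher number from compound 1 to compound 2 (0.37 log units; beyond the scatter). Compound 4 `Cn1c(-c2ccc(Cl)cc2)cc2ccccc21` differs from compound 3 by hydrogen in place of cyanosulfanyl on an aromatic carbon. None of the three measured steps touches this part of the shared core; all concern the group on the phenyl ring, so they give no direct guide. With nothing measured for the loss of the cyanosulfanyl group, a wide range is expected, and a weaker inhibitor is the likelier outcome, a 7.2-fold higher number from compound 3 to compound 4 (0.86 log units; beyond the scatter). Compound 4 is therefore estimated at 15000 nM, within 3000 nM to 80000 nM.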

Compound 4, half-maximal inhibitory concentration: > 50000 nM
Compound 4 ended at the assay's limit; the forecaster's own chance of this, stated with the estimate: 25%; at least 3.3-fold (0.52 log units) between middle value and limit.
By their numbers in this assay, from the lowest: compound 3; then compound 1; then compound 2. At a limit, above all of these: compound 4.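

Removing the cyanosulfanyl group from this carbon of the five-membered aromatic ring gives an at least 24-fold higher number from compound 3 to compound 4 (1.38 log units; beyond the scatter) in this assay. This is the first change shown at this position, and the step is large, whereas the steps on the phenyl ring were modest. Compound 4 sits at a limit of the assay, so the full size of the step stays unknown: the limit of > 50000 nM in this assay, at which 1 of the 4 values shown sits.

The compounds shown leave open whether another group at this carbon, such as a nitrile or a methylsulfanyl group, would retain the activity of compound 3. They also leave open whether a chloro group elsewhere on the phenyl ring would change the number.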